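The source may hold more compounds than are shown below. What is called first, only, known or untested is meant among the compounds shown, and "the series" means these compounds.

Of the compounds shown here, three sharing one core have been read in a functional assay on A549 cells (Homo sapiens) for antiproliferative activity, read by WST assay, with a stated time of 72 h; a lower number here means that less compound is needed, a higher number that more compound is needed for the effect. Compound 1 (`CCCCNCCCCC(=O)Nc1ccc(/C(N)=N/O)cc1`) gives > 1000000 nM, which is a limit of the assay. Compound 3 (`CCCCNCCCC(=O)Nc1ccc(/C(N)=N/O)cc1`) gives > 1000000 nM, which is also a limit and not a number. Going by the values given here, compound 2 (`CCCCNCC(=O)Nc1ccc(/C(N)=N/O)cc1`) gives 395000 nM, the only actual number so far. Compound 3 therefore stands at the limit of > 1000000 nM in this assay, at which 2 of the 3 values shown sit.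

Compound 4 (`CCCCNCCC(=O)Nc1ccc(/C(N)=N/O)cc1`) differs from compound 3 in one place: butylamino in place of (butylamino)methyl on a saturated chain carbon, two bonds along the chain from a carbonyl carbon. In words, this is butylamino in place of (butylamino)methyl on a saturated chain carbon, two bonds along the chain from a carbonyl carbon.

Among the compounds with values here, two measured steps bear on this change. The matching change three bonds along the chain gives a step that the two limits leave unreadable from compound 1 to compound 3, so it offers no size to work from. The wider change, 2-(butylamino)ethyl in place of butylamino on a saturated chain carbon bound to a carbonyl carbon, gives an at least 2.5-fold higher number from compound 2 to compound 3 (0.40 log units; beyond the scatter). That step contains the present difference, so in this assay only part of it is expected to be recovered, and a further limit remains possible. The expected change is an at least 1.5-fold lower number from compound 3 to compound 4 (0.18 log units; that floor lies within the scatter), a modest move toward a lower number. For compound 4 the estimate is 650000 nM, with an expected range from 300000 nM to 1000000 nM.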

Compound 4, half-maximal effective concentration: 881000 nM
For compound 4 the middle estimate is 1.4-fold (0.13 log units) below the measured one; low and high end bracket the measured number.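

In this assay, going by these compounds alone, putting (butylamino)methyl in place of butylamino on a saturated chain carbon bound to a carbonyl carbon gives a 2.2-fold higher number from compound 2 to compound 4 (0.35 log units; beyond the scatter), the first step with an actual number at both ends, and it lies beyond the scatter. Butylamino in place of (butylamino)methyl, two bonds along the chain from a carbonyl carbon, gives an at least 1.1-fold lower number from compound 3 to compound 4 (0.05 log units; that floor lies within the scatter), and butylamino in place of 2-(butylamino)ethyl at that place gives an at least 1.1-fold lower number from compound 1 to compound 4 (0.05 log units; that floor lies within the scatter); both rest on limits of the assay and show only floors within the scatter, so compound 4 cannot be ranked against compound 1 or compound 3. Compound 4 nonetheless gives an actual number in a series where limits are common, and the one change that can be followed on two cores still has no settled size: the same change on two cores in this assay, an at least 2.5-fold higher number (0.40 log units; beyond the scatter) from compound 2 to compound 3 and an at least 1.1-fold higher number (0.05 log units; that floor lies within the scatter) from compound 4 to compound 1; the limit leaves it open whether they differ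

On these data alone, the actual numbers for compound 1 and compound 3 remain unknown, so how far the series continues upward beyond compound 4 stays open. As far as these compounds go, whether a hexylamino or a piperidine group in place of butylamino would follow the same course on these chains also stays open.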